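The source may report more compounds than this note shows. Statements on the series, on what has been measured and on what is new or still open speak of the compounds shown alone.

Measured so far in an assay on isolated protein for binding affinity to 5-hydroxytryptamine receptor 1E (Homo sapiens); on this read-out higher numbers stand for weaker inhibition and lower numbers for stronger inhibition:

compound 1 `Cc1ccc(-c2n[nH]cc2N2CCCNCC2)cc1`: > 10000 nM, a limit of the assay rather than a number
compound 2 `Clc1ccc(-c2n[nH]cc2N2CCCNCC2)cc1`: > 10000 nM, likewise a limit of the assay
compound 3 `Fc1ccc(-c2n[nH]cc2N2CCCNCC2)cc1`: > 10000 nM, again only a limit of the assay

Compound 3 therefore stands at the limit of this assay, not at a measured number. The same is true of the two compounds that share its core, so the three steps between them, a step that the two limits leave unreadable from compound 1 to compound 2, a step that the two limits leave unreadable from compound 1 to compound 3 and a step that the two limits leave unreadable from compound 2 to compound 3, cannot be read in size or direction, because of the limit of > 10000 nM in this assay, at which 3 of the 3 values shown sit.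

Compound 4 `COc1ccc(-c2n[nH]cc2N2CCCNCC2)cc1` differs from compound 3 by methoxy in place of fluoro on an aromatic carbon. Among the compounds with values here, none of the measured steps involves a methoxy group, and the steps that do exist between the methyl, chloro and fluoro analogues are all unreadable, so there is no measured step that bears on this change in a usable way. What the three compounds do show is that varying the group at this position across methyl, chloro and fluoro never brought any of them inside the range of this assay.

On that basis compound 4 is expected to remain at or past the limit as well, with an estimated value of 15000 nM, within 5000 nM to 50000 nM. The step from compound 3 to compound 4 is thus expected to be a step that the limit leaves unreadable from compound 3 to compound 4, meaning no readable change.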

Compound 4, inhibition constant: > 10000 nM
Compound 4 ended at the assay's limit; the forecaster's own chance of this, stated with the estimate: 80%; the middle value lies beyond the limit too.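

The steps from compound 1, compound 2 and compound 3 to compound 4 cannot be read in size or direction, as compound 4 also gives only a limit of the assay: the limit of > 10000 nM in this assay, at which 4 of the 4 values shown sit.

The compounds shown leave open how the methyl, chloro, fluoro and methoxy analogues rank against one another in this assay, and whether any of them would give a readable value there.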